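This account rests on a few compounds, and the source may have more. Where it says the series, first, only, none or still open, it means among the compounds named here.

In an assay on CHO cells for displacement of a labelled ligand from adenosine receptor A1 (Homo sapiens), read by scintillation counting, with a stated time of 120 min, tested at 10 uM (on this read-out higher numbers stand for more inhibition at the one concentration tested (going by the name of the read-out) and lower numbers for less inhibition), compound 3 `Nc1scc(CN2CCN(c3ccc(F)c(F)c3)CC2)c1C(=O)c1ccc(Cl)cc1` gives 0%, and on the numbers shown it stands level with compound 1 `Nc1scc(CN2CCN(c3ccc(Cl)cc3Cl)CC2)c1C(=O)c1ccc(Cl)cc1`, which gives 0%, and with compound 2 `Nc1scc(CN2CCN(c3ccc(Cl)c(C(F)(F)F)c3)CC2)c1C(=O)c1ccc(Cl)cc1`, which gives 0%. Swapping the group on the ring nitrogen among these three compounds moved nothing: the step of no change at the digits printed from compound 1 to compound 2 (within the scatter), the step of no change at the digits printed from compound 1 to compound 3 (within the scatter) and the step of no change at the digits printed from compound 2 to compound 3 (within the scatter) all stay within the scatter. Compound 4 `Nc1scc(CN2CCN(c3cccc(Cl)c3)CC2)c1C(=O)c1ccc(Cl)cc1` carries the change 3-chlorophenyl in place of 3,4-difluorophenyl on an amine nitrogen in a ring at the same point of the structure. All three measured steps bear on this kind of change and none went beyond the scatter, hence no step beyond the scatter is expected for no change at the digits printed from compound 3 to compound 4 (within the scatter) in this assay. Compound 4 is therefore estimated to give 0% in this assay, with an expected range from -8% to 12%.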

Compound 4, a percentage reported as inhibition, at one concentration (the size of the read-out at that concentration, not a potency): 0%
For compound 4 middle estimate and measured number coincide at the digits printed, within the range that was stated.
By their numbers in this assay, from the lowest: compounds 1, 2, 3 and 4 (each within the scatter of the next).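

In this assay, within the data shown here, the steps of no change at the digits printed from compound 3 to compound 4 (within the scatter) and no change at the digits printed from compound 2 to compound 4 (within the scatter) and no change at the digits printed from compound 1 to compound 4 (within the scatter) show that a phenyl with chlorine as its one substituent behaves here like the disubstituted phenyl groups of the earlier compounds. The flat read-out at this amine nitrogen thus extends to 3-chlorophenyl, with fewer heavy atoms than 3,4-difluorophenyl. No measurement at hand accounts for this flatness. Going by these compounds, whether a benzyl, a pyridyl or an acetyl group on this nitrogen, or an amine or a carboxylic acid on the phenyl, would lift the read-out stays open.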